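A few compounds are considered here, and "the series" means these few. Any claim that something is new, unique, unknown or untested is made for them only; others in the source may bear on it.

Compound 1 `NS(=O)(=O)NCC1CCN(c2cc(-c3ccccc3)ncn2)CC1` is one of two closely related compounds tested in a functional assay on MCF7 cells (Homo sapiens) for antiproliferative activity, read by sulforhodamine B assay, with a stated time of 48 h (a lower number here means a stronger inhibitor of growth, a higher number a weaker inhibitor of growth), where compound 1 gives 34300 nM. Compound 2 `NS(=O)(=O)NCC1CCN(c2cc(-c3ccccc3Cl)ncn2)CC1`, which carries chloro in place of hydrogen on an aromatic carbon, gives 62400 nM in this assay. Going by the values given here, the single measured step, a 1.8-fold higher number from compound 1 to compound 2 (0.26 log units; within the scatter), is too small to separate the two, so compound 1 has the lower of the two numbers without standing apart from compound 2. Compound 3 `NS(=O)(=O)NCCC1CCN(c2cc(-c3ccccc3)ncn2)CC1` has not yet been measured. It differs from compound 1 by (sulfamoylamino)methyl in place of sulfamoylamino on a saturated chain carbon bound to a saturated ring carbon; the same difference, cut one bond further out, reads (sulfamoylamino)methyl to 2-(sulfamoylamino)ethyl. Among the compounds with values here, no measured step concerns this lengthening of the chain; the step from compound 1 to compound 2 changes the aromatic part instead and so says little about it, beyond showing that the one small change tried so far stayed within the scatter. For compound 3 the expected step in this assay is a 1.0-fold higher number from compound 1 to compound 3 (0.01 log units; within the scatter), nothing beyond the scatter. Compound 3 is therefore estimated at 35000 nM, with a range from 12000 nM to 100000 nM.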

Compound 3, concentration for 50% growth inhibition: 53200 nM
For compound 3 the middle estimate is 1.5-fold (0.18 log units) below the measured one, and the stated range covers the measured number.
By their numbers in this assay, from the lowest: compounds 1, 3 and 2 (each within the scatter of the next).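

Going from (sulfamoylamino)methyl to 2-(sulfamoylamino)ethyl gives a 1.6-fold higher number from compound 1 to compound 3 (0.19 log units; within the scatter) in this assay, and this is the first reading of any change on the side of the molecule that carries the sulfamoylamino group. The earlier step from compound 1 to compound 2 concerned only the aromatic part, whereas this one shows that adding a single carbon to the chain, on a saturated chain carbon bound to a saturated ring carbon, leaves compound 3 and compound 1 inseparable in this measurement, so for these two chain lengths the length makes no readable difference to growth inhibition. Nothing measured alongside these growth numbers offers an explanation for this result, and a flat step of this kind cannot by itself reveal what the chain does in the cells.

On these data alone, two chain lengths are a narrow test, so it remains open whether a longer chain, such as a propyl or butyl link, or an amine or a carboxylic acid in place of the sulfamoylamino group, would move the number beyond the scatter. As far as these compounds go, it also remains open whether the chloro change and the longer chain would stay this quiet when combined in one compound.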